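Amino for Hydroxy: Expected Shift in Distribution Volume

This account rests on a few compounds, and the source may have more. Where it says the series, first, only, none or still open, it means among the compounds named here.

Compound 2 `N#Cc1ccc(O[C@H]2CN(S(=O)(=O)c3ccc(Cl)cn3)C[C@@]2(O)CO)cc1F` and compound 1 `N#Cc1ccc(O[C@H]2CN(S(=O)(=O)c3ccc(Cl)cc3Cl)C[C@@]2(O)CN)cc1F` were each studied in an ADME assay on the whole organism (Rattus norvegicus, strain Sprague-Dawley) for pharmacokinetics, read by LC-MS, with a stated time of 30 min; a higher number here means that more of the compound sits outside the plasma, a lower number that more of the compound stays in the plasma. Compound 1 gives 7.7 L/kg, while compound 2 gives 2.2 L/kg, the lower of the two numbers and beyond the scatter apart from compound 1. Compound 3 `N#Cc1ccc(O[C@H]2CN(S(=O)(=O)c3ccc(Cl)cn3)C[C@@]2(O)CN)cc1F` has not yet been measured. It differs from compound 2 in one place: amino in place of hydroxy on a saturated chain carbon bound to a saturated ring carbon. For the measured compounds named here, no measured pair shows this same change, so the direction rests on little. Because compound 1 gives 7.7 L/kg, far above compound 2, compound 3 is expected to move upward, a step of a 2.3-fold higher number from compound 2 to compound 3 (0.36 log units; beyond the scatter). Compound 3 is estimated at 5 L/kg, within 2.5 L/kg to 10 L/kg.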

Compound 3, volume of distribution at steady state: 6.7 L/kg
For compound 3 the middle estimate is 1.3-fold (0.13 log units) below the measured one, and the stated range covers the measured number.
By their numbers in this assay, from the lowest: compound 2; then compounds 3 and 1 (each within the scatter of the next).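

In this assay, hydroxymethyl to aminomethyl now has a direct reading with the 5-chloropyridin-2-yl group held fixed, and the number rises beyond the scatter (a 3.0-fold higher number from compound 2 to compound 3 (0.48 log units; beyond the scatter)). Exchanging the group on the sulfonyl sulfur, with aminomethyl held fixed, leaves the two numbers indistinguishable (a 1.1-fold lower number from compound 1 to compound 3 (0.06 log units; within the scatter)). No measurement shown explains the rise.

Going by these compounds, it remains open how a dimethylamino group or a longer chain such as aminoethyl would behave at this place. On these data alone, it is also open whether hydroxymethyl to aminomethyl gives a similar step with 2,4-dichlorophenyl on the sulfonyl sulfur.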